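A few compounds are considered here, and "the series" means these few. Any claim that something is new, unique, unknown or untested is made for them only; others in the source may bear on it.

Compound 1 `COc1ccc(CCOc2ccc(-c3c(C)nc(C)c([C@H](OC(C)(C)C)C(=O)O)c3N3CCC(C)(C)CC3)cc2)cc1`: > 2 h
Compound 2 `Cc1nc(C)c([C@H](OC(C)(C)C)C(=O)O)c(N2CCC(C)(C)CC2)c1-c1ccc(OCCCc2ccc(F)cc2)cc1`: > 2 h

In an ADME assay on microsomes from liver (Homo sapiens) for metabolic stability, read by LC-MS, tested at 0.5 uM (a higher number here means that the compound lasts longer, a lower number that the compound disappears faster), compound 1 gives > 2 h, which is a limit of the assay rather than a number. In this assay compound 2 likewise gives > 2 h, again a limit. Compound 2 therefore stands where every value shown stands: the limit of > 2 h in this assay, at which 2 of the 2 values shown sit. For the measured compounds named here, the one measured step, a step that the two limits leave unreadable from compound 1 to compound 2, cannot be read because both of its ends sit at that limit (the limit of > 2 h in this assay, at which 2 of the 2 values shown sit).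

Compound 3 `Cc1nc(C)c([C@H](OC(C)(C)C)C(=O)O)c(N2CCC(C)(C)CC2)c1-c1ccc(OC2COCC2c2ccc(F)cc2)cc1` differs from compound 2 by 4-(4-fluorophenyl)oxolan-3-yl in place of 3-(4-fluorophenyl)propyl on an oxygen on an aromatic ring. No measured step bears on this change, as the only step shown, a step that the two limits leave unreadable from compound 1 to compound 2, is unreadable. The expectation for compound 3 therefore rests on where compound 2 sits: compound 3 is expected to stay near the limit, with an estimated step that the limit leaves unreadable from compound 2 to compound 3. Compound 3 is thus estimated at 2.5 h in this assay, with a range from 0.8 h to 6 h.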

Compound 3, half-life: 0.783 h
The estimate for compound 3 lay 3.2-fold (0.50 log units) above the measured number, outside the stated range (below it).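

In this assay, for the compounds shown here, 4-(4-fluorophenyl)oxolan-3-yl in place of 3-(4-fluorophenyl)propyl gives the first readable step on this oxygen on an aromatic ring: an at least 2.5-fold lower number from compound 2 to compound 3 (0.40 log units; beyond the scatter). In place of 2-(4-methoxyphenyl)ethyl, the same group gives an at least 2.5-fold lower number from compound 1 to compound 3 (0.40 log units; beyond the scatter), so the lower number holds against both open chains shown. From the compounds shown here alone, the full size of these two steps stays unknown and the step between the two open-chain compounds cannot be read, because those compounds sit at a limit of the assay: the limit of > 2 h in this assay, at which 2 of the 3 values shown sit.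

The compounds shown leave open whether the lower number goes with the oxygen of the oxolane or with the ring as such, a question that a cyclopentyl ring carrying the same 4-fluorophenyl would address. They also leave open how a hydroxyl or an amine on the propyl chain would read in this assay.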